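Methoxy in Place of Methyl: An Expected Step

The compounds below may be only part of what the source reports. "The series", "measured", "known", "first", "only" and "open" are said of these compounds alone.

Compound 1, `Cc1ccc(S(=O)(=O)Oc2ccccc2/C=C(\C#N)C(=O)Nc2nnc(Cc3cccc4ccccc34)s2)cc1`: 73%
Compound 2, `COc1ccc(S(=O)(=O)Oc2ccccc2/C=C(\C#N)C(=O)Nc2nnc(Cc3cccc4ccccc34)s2)cc1`: 78%
Compound 3, `Cc1ccc(S(=O)(=O)Oc2ccccc2/C=C(\C#N)C(=O)Nc2nnc(Cc3ccc(Cl)cc3)s2)cc1`: 69%

All three were tested in a functional assay on RS4-11 cells (Homo sapiens) for inhibition, read by CCK-8 assay, with a stated time of 48 h, tested at 20 uM; on this read-out lower numbers stand for less inhibition of growth and higher numbers for more inhibition of growth at the one concentration tested. Compound 1 and compound 2 share a core and differ only by methoxy in place of methyl on an aromatic carbon; that change gave a number 5 percentage points higher from compound 1 to compound 2 (within the scatter). Compound 3 differs from compound 1 by 4-chlorophenyl in place of naphthalen-1-yl on a saturated chain carbon bound to an aromatic carbon, and that change gave a number 4 percentage points lower from compound 1 to compound 3 (within the scatter). Compound 4, `COc1ccc(S(=O)(=O)Oc2ccccc2/C=C(\C#N)C(=O)Nc2nnc(Cc3ccc(Cl)cc3)s2)cc1`, has not yet been tested; it carries the same change as compound 2 does, now on the core of compound 3: methoxy in place of methyl on an aromatic carbon. This change occurs twice among the four compounds, once measured. That measured step, a number 5 percentage points higher from compound 1 to compound 2 (within the scatter), lay within the scatter. Resting on that, the step expected for compound 4 in this assay is a number 4 percentage points higher from compound 3 to compound 4 (within the scatter). Compound 4 is estimated to reach 73%, with a likely range from 62% to 84%.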

Compound 4, percent growth inhibition at one concentration: 77%
Compound 4: middle estimate off by 4 percentage points, on the low side, within the range that was stated.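

In this assay, methoxy in place of methyl gave a number 8 percentage points higher from compound 3 to compound 4 (within the scatter), which agrees with the same change on the core of compound 1: the same change on two cores in this assay, a number 5 percentage points higher (within the scatter) from compound 1 to compound 2 and a number 8 percentage points higher (within the scatter) from compound 3 to compound 4, 3 percentage points apart, within the scatter of two such steps. Likewise, 4-chlorophenyl in place of naphthalen-1-yl gave a number 1 percentage points lower from compound 2 to compound 4 (within the scatter), which agrees with the earlier step: the same change on two cores in this assay, a number 4 percentage points lower (within the scatter) from compound 1 to compound 3 and a number 1 percentage points lower (within the scatter) from compound 2 to compound 4, 3 percentage points apart, within the scatter of two such steps. This shows that each change gave matching steps on the two cores tested, but with every step within the scatter, it does not show that either change truly alters growth inhibition, nor that the agreement extends to other cores.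

Still open, as far as these compounds go, is whether an amine or a carboxylic acid in place of methoxy on that aromatic carbon would give a step beyond the scatter. The compounds shown also leave open how a longer chain in place of methoxy would read.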